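Compound 3 to compound 4: iodo replaces methylcarbamoyl

The source may report more compounds than this note shows. Statements on the series, on what has been measured and on what is new or still open speak of the compounds shown alone.

Measured in an ADME assay on J774 cells (Mus musculus) for cytotoxicity; a higher number here means that more compound is needed for the effect, a lower number that less compound is needed:
- compound 1 `CCCCc1cc2c(=O)c(C#N)c[nH]c2cc1OCCOc1ccccc1`: > 20000 nM (a limit)
- compound 2 `CCCCc1cc2c(=O)c(C(=O)O)c[nH]c2cc1OCCOc1ccccc1`: > 20000 nM (a limit)
- compound 3 `CCCCc1cc2c(=O)c(C(=O)NC)c[nH]c2cc1OCCOc1ccccc1`: > 20000 nM (a limit)

In this assay compound 3 gives > 20000 nM as a limit and not a number. Within the data shown here, the series so far shows only the limit of > 20000 nM in this assay, at which 3 of the 3 values shown sit, and no number to rank the compounds by.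

The move to compound 4 `CCCCc1cc2c(=O)c(I)c[nH]c2cc1OCCOc1ccccc1` puts iodo in place of methylcarbamoyl on an aromatic carbon. Iodo has not been measured on this carbon.

Among the measured compounds shown here, the steps that bear on it all change the group on the same aromatic carbon. They are a step that the two limits leave unreadable from compound 1 to compound 2 and a step that the two limits leave unreadable from compound 1 to compound 3 and a step that the two limits leave unreadable from compound 2 to compound 3 and none of them has a readable size. The expectation therefore rests only on the shared limit, since the limit of > 20000 nM in this assay, at which 3 of the 3 values shown sit, holds for compound 1 and compound 2 and compound 3 alike.

The expected move is a number no higher from compound 3 to compound 4 (the limit leaves the size open) and no change beyond the scatter is anticipated in this assay on this evidence. For compound 4 the estimate is 20000 nM with an expected range from 10000 nM to 40000 nM and a reading as a limit is the likeliest result.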

Compound 4, half-maximal effective concentration: > 10000 nM
Compound 4 gave a limit, no number; the forecaster's own chance of this, stated with the estimate: 75%; the middle value does not contradict the limit.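

In this assay compound 4 gives > 10000 nM, a limit and not a number. Its steps to compound 1, compound 2 and compound 3 cannot be read, as all four values are limits. The compounds shown leave open whether iodo, cyano, carboxy and methylcarbamoyl on this aromatic carbon differ at all in this assay.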